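This account rests on a few compounds, and the source may have more. Where it says the series, first, only, none or still open, it means among the compounds named here.

Values measured so far in a functional assay on Vero cells (Chlorocebus sabaeus) for inhibition (a higher number here means a weaker inhibitor, a lower number a stronger inhibitor), are these:
- Compound 1 (`Clc1ccc(Cn2cnc3c(-c4ccco4)ncnc32)cc1`) gives > 62.5 ug/mL as a limit.
- Compound 2 (`Clc1cccc(Cn2cnc3c(-c4ccco4)ncnc32)c1`) gives > 10 ug/mL as a limit.
- Compound 3 (`Fc1ccccc1Cn1cnc2c(-c3ccco3)ncnc21`) gives > 10 ug/mL as a limit.

Compound 1 has no exact number, only a limit, and it stands alone at that limit (the limit of > 62.5 ug/mL in this assay, at which 1 of the 3 values shown sits). The other two compounds share a different limit (the limit of > 10 ug/mL in this assay, at which 2 of the 3 values shown sit).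

Compound 4 (`COc1ccc(Cn2cnc3c(-c4ccco4)ncnc32)cc1`) keeps the core of compound 1 and differs in one group (methoxy in place of chloro on an aromatic carbon), with methoxy in place of chloro on an aromatic carbon.

Three measured steps change the group on the same phenyl ring: a step that the two limits leave unreadable from compound 1 to compound 2 and a step that the two limits leave unreadable from compound 1 to compound 3, along with a step that the two limits leave unreadable from compound 2 to compound 3 as well. None of them has a readable size, so they offer no figure to carry over to the new change. Going by the values given here, they show only that all three compounds ended in a limit.

The closest neighbour is compound 1 at > 62.5 ug/mL as a limit, so no step beyond the scatter is expected in this assay in either direction. Another limit is the likeliest report for compound 4.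

The expected change is an at least 1.0-fold lower number from compound 1 to compound 4 (0.01 log units; that floor lies within the scatter) on this estimate.

For compound 4 the estimated value is 60 ug/mL in the middle, with an expected range from 15 ug/mL to 150 ug/mL for now.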

Compound 4, half-maximal inhibitory concentration: > 62.5 ug/mL
Compound 4: no number, only a limit; the forecaster's own chance of this, stated with the estimate: 75%; middle value at least 1.0-fold (0.01 log units) from the limit.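

In this assay compound 4 gives > 62.5 ug/mL as a limit and not a number. Compound 1 also ends in a limit, so no size can be read for the step between compound 1 and compound 4, where methoxy replaces chloro. The compounds shown leave open how strongly any of them inhibits and whether the group on the phenyl ring changes that.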